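The source may report more compounds than this note shows. Statements on the series, on what has been measured and on what is new or still open speak of the compounds shown alone.

In an ADME assay on HepG2 cells (Homo sapiens) for cytotoxicity, in the presence of a further agent that is not named here (on this read-out lower numbers stand for stronger inhibition and higher numbers for weaker inhibition), compound 2 (`Cn1c(Cc2ccccc2C(F)(F)F)nc(C(=O)CCc2ccccc2)c(O)c1=O`) stands only at a limit, > 100000 nM. Compound 1 (`Cn1c(Cc2ccccc2C(F)(F)F)nc(C(=O)NCc2cccnc2)c(O)c1=O`) also gives only a limit, > 100000 nM. Within the data shown here, the one measured step, a step that the two limits leave unreadable from compound 1 to compound 2, has no readable size, and the evidence amounts to the limit of > 100000 nM in this assay, at which 2 of the 2 values shown sit. Compound 3 (`Cn1c(Cc2ccccc2C(F)(F)F)nc(C(=O)NCc2ccccc2F)c(O)c1=O`) differs from compound 2 by one change: (2-fluorobenzyl)amino in place of phenethyl on a carbonyl carbon. Like compound 1, it has an amino group on that carbonyl carbon, so no step beyond the scatter is expected in this assay, in either direction. The expected change is a number no higher from compound 2 to compound 3 (the limit leaves the size open). For compound 3 the estimate is 100000 nM, with an expected range of 40000 nM to 250000 nM.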

Compound 3, half-maximal inhibitory concentration: > 100000 nM
Compound 3 gave a limit, no number; the forecaster's own chance of this, stated with the estimate: 85%; the middle value sits exactly at the limit.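

Compound 3, like compound 1 and compound 2, gives only a limit in this assay, so no new step can be read among them. The compounds shown leave open whether any change on the carbonyl carbon shifts this read-out at all.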